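A few compounds are considered here, and "the series" means these few. Any claim that something is new, unique, unknown or untested is made for them only; others in the source may bear on it.

Working notes on the series, which shares one core. Compound 3 `CC(=O)c1ccc(NC(=O)CSc2nnc(-c3ccoc3C)n2Cc2ccco2)cc1` gives in a functional assay on CHO cells for antagonist activity at Orexin receptor type 2 (Homo sapiens), read by FLIPR and calcium flux (on this read-out lower numbers stand for stronger inhibition and higher numbers for weaker inhibition), the value 31.6 nM, the lowest of the three numbers measured. Compound 2 `Cc1occc1-c1nnc(SCC(=O)Nc2ccc(Cl)cc2)n1Cc1ccco1` gives 100 nM in this assay, and compound 1 `Cc1occc1-c1nnc(SCC(=O)Nc2ccc(F)cc2)n1Cc1ccco1` gives 158 nM. The steps of a 1.6-fold lower number from compound 1 to compound 2 (0.20 log units; within the scatter), a 5.0-fold lower number from compound 1 to compound 3 (0.70 log units; beyond the scatter) and a 3.2-fold lower number from compound 2 to compound 3 (0.50 log units; beyond the scatter) all concern the substituent on an aromatic carbon of the 4-acetylphenyl group. Compound 4 `Cc1occc1-c1nnc(SCC(N)=O)n1Cc1ccco1` differs from compound 3 by hydrogen in place of 4-acetylphenyl on an amide-type nitrogen. Among the measured compounds shown here, no measured step removes the whole aryl group, so none bears directly on this change; the three steps only show that varying its substituent moves the number modestly. Removing the entire group is a larger change, and a marked rise in the number is expected for compound 4: a 95-fold higher number from compound 3 to compound 4 (1.98 log units; beyond the scatter). The estimate for compound 4 in this assay is 3000 nM, with a range from 500 nM to 20000 nM.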

Compound 4, inhibition constant: > 15800 nM
Compound 4 ended at the assay's limit; the forecaster's own chance of this, stated with the estimate: 40%; middle value at least 5.2-fold (0.72 log units) away from the limit.
By their numbers in this assay, from the lowest: compound 3; then compounds 2 and 1 (each within the scatter of the next). At a limit, above all of these: compound 4.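

Compound 4 stands at a limit of this assay, not at a number: the limit of > 15800 nM in this assay, at which 1 of the 4 values shown sits. Among the compounds shown here, the substituent changes among the earlier compounds moved the number only modestly, whereas hydrogen in place of the whole aryl group on the amide-type nitrogen gives an at least 500-fold higher number from compound 3 to compound 4 (2.69 log units; beyond the scatter), an at least 150-fold higher number from compound 2 to compound 4 (2.19 log units; beyond the scatter) and an at least 100-fold higher number from compound 1 to compound 4 (2.00 log units; beyond the scatter). At this position, the presence of the aryl group therefore matters far more than its substituent.

As far as these compounds go, whether a plain phenyl, a cyclohexyl or a methyl on that nitrogen would keep the lower numbers remains open. So does the true size of these three steps.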